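Chloro to Fluoro on a Small Calpain-1 Inhibitor

A few compounds are considered here, and "the series" means these few. Any claim that something is new, unique, unknown or untested is made for them only; others in the source may bear on it.

Compound 1 `O=C(O)/C(S)=C/c1ccc(Cl)cc1`: 15000 nM
Compound 2 `O=C(O)/C(S)=C/c1cccc(F)c1`: 31500 nM

Of the compounds shown here, two built on a shared core have so far been tested in an assay on isolated protein for inhibition of Calpain-1 catalytic subunit (Sus scrofa); a lower number here means a stronger inhibitor, a higher number a weaker inhibitor. Compound 1 `O=C(O)/C(S)=C/c1ccc(Cl)cc1` gives 15000 nM, the lowest number of the two. Compound 2 `O=C(O)/C(S)=C/c1cccc(F)c1` gives 31500 nM, a higher number, and the gap between the two lies beyond the usual scatter of repeated measurements. Compound 3 `O=C(O)/C(S)=C/c1ccc(F)cc1` has not yet been measured. It differs from compound 1 in a single place: fluoro in place of chloro on an aromatic carbon. Among the compounds with values here, no measured pair shows this exact change, so its effect on the numbers is not known from these data; what is known is only that the two measured compounds, which carry different halogens at different places on the ring, differ by a step beyond the scatter. The expectation for compound 3 is a modest rise in the number, a step of a 1.7-fold higher number from compound 1 to compound 3 (0.22 log units; within the scatter) that may or may not exceed the scatter. Compound 3 is thus estimated at 25000 nM, with a likely range from 10000 nM to 60000 nM.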

Compound 3, half-maximal inhibitory concentration: 5600 nM
For compound 3 the middle estimate is 4.5-fold (0.65 log units) above the measured one; the whole stated range lies above it.
By their numbers in this assay, from the lowest: compound 3; then compound 1; then compound 2.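

This position on the ring is sensitive to which halogen it carries: with fluoro in place of chloro on the aromatic carbon, the number in this assay falls, a change of a 2.7-fold lower number from compound 1 to compound 3 (0.43 log units; beyond the scatter). The swap exchanges one heavy atom for one heavy atom, and neither group brings a ring, a hydrogen-bond donor or acceptor, or a net charge, yet that small edit is enough to move the number beyond the scatter. Nothing measured here explains why fluoro gives the lower number.

From the compounds shown here alone, what an amine, a methoxy group or a nitrile would give at this same place on the ring remains open, so the series does not yet show whether fluoro is the best choice there. Also open, going by these compounds, is what an amide in place of the carboxylic acid would do on the shared core.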